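The compounds below may be only part of what the source reports. "The series", "measured", "known", "first", "only" and "open" are said of these compounds alone.

Compound 1 `CC1CCC(Nc2nc(C(F)(F)F)ccc2CNC(=O)C(C)c2ccc(NS(C)(=O)=O)c(F)c2)CC1` gives 1130 nM in a functional assay on CHO-K1 cells for antagonist activity at transient receptor potential cation channel subfamily V member 1 (Homo sapiens), read by FLIPR; on this read-out lower numbers stand for stronger inhibition and higher numbers for weaker inhibition. Within the data shown here, compound 2 `CC(C(=O)NCc1ccc(C(F)(F)F)nc1Nc1ccccc1)c1ccc(NS(C)(=O)=O)c(F)c1` gives 1400 nM in this assay; the only other number available is that of compound 1, and the step of a 1.2-fold higher number from compound 1 to compound 2 (0.09 log units; within the scatter) leaves the two compounds within the usual scatter of each other. Compound 3 `CC(C(=O)NCc1ccc(C(F)(F)F)nc1NCc1ccccc1)c1ccc(NS(C)(=O)=O)c(F)c1` differs from compound 2 by benzyl in place of phenyl on a nitrogen on an aromatic ring. Among the measured compounds shown here, the single step that touches this same nitrogen, a 1.2-fold higher number from compound 1 to compound 2 (0.09 log units; within the scatter), stayed within the scatter, so no change beyond the scatter is expected for no change at the digits printed from compound 2 to compound 3 (within the scatter). Compound 3 is estimated at 1400 nM in this assay, within a range of 500 nM to 4000 nM.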

Compound 3, half-maximal inhibitory concentration: 203 nM
The estimate for compound 3 lay 6.9-fold (0.84 log units) above the measured number; measured number outside the range, below it.
By their numbers in this assay, from the lowest: compound 3; then compounds 1 and 2 (each within the scatter of the next).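

In this assay benzyl in place of phenyl on this nitrogen brings a 6.9-fold lower number from compound 2 to compound 3 (0.84 log units; beyond the scatter) and benzyl in place of 4-methylcyclohexyl brings a 5.6-fold lower number from compound 1 to compound 3 (0.75 log units; beyond the scatter) so this position does respond to its group. The earlier swap between the two directly attached rings had stayed within the scatter, and only benzyl stands apart. Nothing measured here says why.

Going by these compounds, whether a longer chain such as 2-phenylethyl would lower the number further remains open. So does whether a substituted benzyl, such as 4-fluorobenzyl, would keep the gain.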